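Cytotoxicity notes on the pyrazole amine series

A few compounds are considered here, and "the series" means these few. Any claim that something is new, unique, unknown or untested is made for them only; others in the source may bear on it.

Measured so far:
compound 1 `CN1CCN(CCCNCc2cn(-c3ccc(C(F)(F)F)cc3)nc2-c2ccc(OC(F)(F)F)cc2)CC1`: 2300 nM
compound 2 `CN1CCN(CCNCc2cn(-c3ccc(F)cc3F)nc2C2CCCCC2)CC1`: > 20000 nM
compound 3 `Cc1ccccc1-c1nn(-c2ccc(Br)cc2)cc1CNCCN1CCN(C)CC1`: 9600 nM

In an ADME assay on Huh-7 cells (Homo sapiens) for cytotoxicity (on this read-out higher numbers stand for lower toxicity in this test and lower numbers for higher toxicity in this test), compound 2 reports only a limit, > 20000 nM, not a number. This places compound 2 at the limit of > 20000 nM in this assay, at which 1 of the 3 values shown sits. Compound 1 and compound 3 both give numbers in this assay, with compound 1 sitting lower than compound 3.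

Compound 4 `Cc1ccccc1-c1nn(-c2ccc(F)cc2F)cc1CNCCN1CCN(C)CC1` is not yet measured. It differs from compound 2 in one place: 2-methylphenyl in place of cyclohexyl on an aromatic carbon. Among the compounds with values here, no pair of measured compounds differs in just this way, so the size of the step is open. Compound 3, which carries the same 2-methylphenyl, gives a number rather than a limit in this assay, so a modest move toward higher toxicity is expected, if any. Compound 4 is expected at about 14000 nM in this assay, likely between 5000 nM and 40000 nM, a step of an at least 1.4-fold lower number from compound 2 to compound 4 (0.15 log units; that floor lies within the scatter) from the limit of compound 2.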

Compound 4, half-maximal cytotoxic concentration: > 20000 nM
Compound 4: no number, only a limit; the forecaster's own chance of this, stated with the estimate: 40%; middle value at least 1.4-fold (0.15 log units) from the limit.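

In this assay, the 2-methylphenyl group on the aromatic carbon does not by itself bring a number: compound 4 carries it and reports only a limit, > 20000 nM. With that group held, 2,4-difluorophenyl in place of 4-bromophenyl on the aromatic nitrogen gives an at least 2.0-fold higher number from compound 3 to compound 4 (0.31 log units; beyond the scatter). The step between compound 2 and compound 4 cannot be read, and the limit now covers more of the set: the limit of > 20000 nM in this assay, at which 2 of the 4 values shown sit.

Still open, from the compounds shown here alone, is whether 2,4-difluorophenyl stays at the limit with other groups on the aromatic carbon. An amine or a carboxylic acid at that place would test this.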